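The compounds below may be only part of what the source reports. "The series", "measured", "known", "first", "only" and "open" are said of these compounds alone.

Compound 2 `OC[C@H]1O[C@@H](n2cnc3c(NCc4ccc(Cl)cc4)ncnc32)[C@H](O)[C@@H]1O` is one of three close relatives that share the same core and differ only in the aromatic group attached to the saturated chain carbon bound to the amine nitrogen. In a functional assay on HL-60 cells (Homo sapiens) for antiproliferative activity, with a stated time of 72 h (a lower number here means a stronger inhibitor, a higher number a weaker inhibitor), compound 2 gives 1700 nM. That places it second highest of the three numbers: compound 1 `OC[C@H]1O[C@@H](n2cnc3c(NCc4cccc(F)c4)ncnc32)[C@H](O)[C@@H]1O` gives 920 nM, and the step of a 1.8-fold higher number from compound 1 to compound 2 (0.27 log units; within the scatter) stays within the scatter, so the two cannot be ranked against each other; compound 3 `OC[C@H]1O[C@@H](n2cnc3c(NCc4ccccc4Br)ncnc32)[C@H](O)[C@@H]1O` gives 6600 nM, and the step of a 3.9-fold higher number from compound 2 to compound 3 (0.59 log units; beyond the scatter) is beyond the scatter, so compound 3 is the weaker of that pair.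

The change to compound 4 `OC[C@H]1O[C@@H](n2cnc3c(NCc4ccc(Cl)c(Cl)c4)ncnc32)[C@H](O)[C@@H]1O` is chloro in place of hydrogen on an aromatic carbon, taking the group from 4-chlorobenzyl to 3,4-dichlorobenzyl. Among the measured compounds shown here, none of the measured steps adds a second halogen to a ring that already carries one. The nearest guide is the step of a 1.8-fold higher number from compound 1 to compound 2 (0.27 log units; within the scatter), which shows that a single halogen at either of the two positions now occupied gives numbers within the scatter of each other; the steps of a 7.2-fold higher number from compound 1 to compound 3 (0.86 log units; beyond the scatter) and a 3.9-fold higher number from compound 2 to compound 3 (0.59 log units; beyond the scatter) concern a different position and do not bear directly on this change.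

Compound 4 is therefore expected to give 1300 nM in this assay, within a range from 500 nM to 3500 nM. The expected step is a 1.3-fold lower number from compound 2 to compound 4 (0.12 log units; within the scatter), which is not beyond the scatter.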

Compound 4, half-maximal inhibitory concentration: 2000 nM
Compound 4: middle estimate off by 1.5-fold (0.19 log units), on the low side; measured number inside the range.
By their numbers in this assay, from the lowest: compounds 1, 2 and 4 (each within the scatter of the next, the first and the last beyond it); then compound 3.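

In this assay, among the compounds shown here, a second chloro group on the ring that already carries one gives a 1.2-fold higher number from compound 2 to compound 4 (0.07 log units; within the scatter) and so cannot be told apart from the single chloro group: this aromatic carbon, ortho to a chloro group, takes the added atom while the number stays in the same range. The 3,4-dichlorobenzyl group also keeps the clear advantage over the 2-bromobenzyl group, with a 3.3-fold lower number from compound 3 to compound 4 (0.52 log units; beyond the scatter) in this series, yet it shows a 2.2-fold higher number from compound 1 to compound 4 (0.34 log units; beyond the scatter). Compound 1 and compound 2, each with a single halogen, could not be ranked against each other, so small gaps that are each within the scatter can add up to one just beyond it. Nothing measured here explains why these numbers fall as they do.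

For the compounds shown here, what a methoxy group, an amine or a carboxylic acid on this same aromatic carbon would give remains open, since chloro is the only group seen there. Whether a bromo group or a longer chain at this carbon would also stay in this range is equally unanswered by these four compounds.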